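Swapping the aryl group to curb clearance

The source may report more compounds than this note shows. Statements on the series, on what has been measured and on what is new or still open speak of the compounds shown alone.

Measured compounds in an ADME assay (liver) for metabolic stability, with Liver microsome (Homo sapiens) as the target, using microsomes and NADPH, with a stated time of 30 min, tested at 1 uM; on this read-out lower numbers stand for slow clearance and higher numbers for fast clearance:
- compound 1, `Nc1ccc(S(=O)(=O)N2CCN(c3ncc(C(O)(C(F)(F)F)C(F)(F)F)cc3C#CC3CC3)CC2)cn1`: this value is an assay limit, < 14 mL.min-1.g-1
- compound 2, `CC(C)(C)n1cc(-c2cc(C(O)(C(F)(F)F)C(F)(F)F)cnc2N2CCN(S(=O)(=O)c3ccc(N)nc3)CC2)cn1`: 86 mL.min-1.g-1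
- compound 3, `Nc1ccc(S(=O)(=O)N2CCN(c3ncc(C(O)(C(F)(F)F)C(F)(F)F)cc3-c3cccnc3)CC2)cn1`: 17 mL.min-1.g-1

Compound 2 stands at the highest number of the two that were reported as numbers, and compound 3 sits at a 5.1-fold lower number from compound 2 to compound 3 (0.70 log units; beyond the scatter). Compound 1 gives only a limit, (the limit of < 14 mL.min-1.g-1 in this assay, at which 1 of the 3 values shown sits).

Compound 4, `COc1cncc(-c2cc(C(O)(C(F)(F)F)C(F)(F)F)cnc2N2CCN(S(=O)(=O)c3ccc(N)nc3)CC2)c1`, differs from compound 2 in one place: 5-methoxypyridin-3-yl in place of 1-(tert-butyl)-1H-pyrazol-4-yl on an aromatic carbon.

The step that bears most on this change is the one where a pyridin-3-yl also replaced the 1-(tert-butyl)-1H-pyrazol-4-yl group, a 5.1-fold lower number from compound 2 to compound 3 (0.70 log units; beyond the scatter), a modest drop that lies beyond the scatter. Compound 4 carries a 5-methoxypyridin-3-yl group rather than a plain pyridin-3-yl, so the closest guide is compound 3, with the added methoxy group untested in this set. The expectation for compound 4 is therefore a decrease of similar size, a 3.4-fold lower number from compound 2 to compound 4 (0.54 log units; beyond the scatter), in this assay .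

Compound 4 is estimated at 25 mL.min-1.g-1, with a likely range from 12 mL.min-1.g-1 to 55 mL.min-1.g-1.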

Compound 4, intrinsic clearance in microsomes: 44 mL.min-1.g-1
Compound 4: the middle estimate sits 1.8-fold (0.25 log units) below what was measured, within the range that was stated.
By their numbers in this assay, from the lowest: compound 3; then compounds 4 and 2 (each within the scatter of the next). At a limit, below all of these: compound 1.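

The new information is what a single added group does: in this assay, putting methoxy on the pyridin-3-yl group gives a 2.6-fold higher number from compound 3 to compound 4 (0.41 log units; beyond the scatter), so this small addition changes clearance by a modest but real amount. Set against the 1-(tert-butyl)-1H-pyrazol-4-yl group, the 5-methoxypyridin-3-yl group gives a 2.0-fold lower number from compound 2 to compound 4 (0.29 log units; within the scatter), so this pair cannot be told apart in this assay, whereas the plain pyridin-3-yl group did stand clear of the pyrazole. The 5-methoxypyridin-3-yl group does stand clear of the 2-cyclopropylethynyl group, with an at least 3.1-fold higher number from compound 1 to compound 4 (0.49 log units; beyond the scatter), and that size is only a floor, not a measured gap: the limit of < 14 mL.min-1.g-1 in this assay, at which 1 of the 4 values shown sits.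

The compounds shown leave open whether this rise belongs to the methoxy group itself or would come with almost any group added to the pyridin-3-yl ring, and whether it depends on where on the ring that group sits. A fluorine, a nitrile or a longer ethoxy chain on the same ring would help to separate these readings.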